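Compound 3 to compound 4: swapping the acyl group

This account rests on a few compounds, and the source may have more. Where it says the series, first, only, none or still open, it means among the compounds named here.

In a functional assay on cells (Homo sapiens) for inhibition, read by MTT assay, with a stated time of 72 h (on this read-out higher numbers stand for weaker inhibition and lower numbers for stronger inhibition), compound 3 `O=C(O)Cn1ncc2c(Nc3ccc(NC(=O)c4ccccc4)cc3)ncnc21` gives only a limit, > 100 ug/mL. Compound 2 `O=C(O)Cn1ncc2c(Nc3ccc(NS(=O)(=O)c4ccccc4)cc3)ncnc21` also gives only a limit, > 100 ug/mL. For the measured compounds named here, the one measured step, a step that the two limits leave unreadable from compound 2 to compound 3, therefore offers no size to carry forward. Compound 4 `O=C(O)Cn1ncc2c(Nc3ccc(NC(=O)CCl)cc3)ncnc21` has chloromethyl in place of phenyl on a carbonyl carbon. Compound 1 `CCOC(=O)Cn1ncc2c(Nc3ccc(NC(=O)CCl)cc3)ncnc21` carries the same (chloromethyl)carbonyl group but is an ethyl ester rather than an acid, and compound 1 gives 3.51 ug/mL. On the strength of that value, stronger inhibition is expected, though short of compound 1, and a limit remains possible. The expected step is an at least 4.0-fold lower number from compound 3 to compound 4 (0.60 log units; beyond the scatter). The estimate for compound 4 is 25 ug/mL, with an expected range of 5 ug/mL to 100 ug/mL.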

Compound 4, half-maximal inhibitory concentration: > 100 ug/mL
Compound 4: only a limit was reported; the forecaster's own chance of this, stated with the estimate: 35%; at least 4.0-fold (0.60 log units) between middle value and limit.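

In this assay compound 4 gives > 100 ug/mL, which is a limit. The steps to it from compound 2 and compound 3 cannot be read, so chloromethyl in place of phenyl on a carbonyl carbon shows no readable change among the acids. New is an at least 28-fold higher number from compound 1 to compound 4 (1.45 log units; beyond the scatter), with hydrogen in place of ethyl on an oxygen next to a carbonyl group, so (chloromethyl)carbonyl gives a measurable value here only with the ethyl ester, and the acids shown all stay at one limit: the limit of > 100 ug/mL in this assay, at which 3 of the 4 values shown sit.

Open, as far as these compounds go, is whether benzoyl or phenylsulfonyl would also give a measurable value with the ethyl ester. Also open, from the compounds shown here alone, is whether a methyl ester or a primary amide in place of the acid would behave like the ethyl ester.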